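The source may hold more compounds than are shown below. What is called first, only, known or untested is meant among the compounds shown, and "the series" means these compounds.

Compound 1 `Nc1scc(CN2CCN(c3ccc([N+](=O)[O-])cc3)CC2)c1C(=O)c1ccc(Cl)cc1`: -17%
Compound 2 `Nc1scc(CN2CCN(c3cccc4ccccc34)CC2)c1C(=O)c1ccc(Cl)cc1`: -21%

In a functional assay on CHO cells with adenosine receptor A1 (Homo sapiens) as the target, read by cAMP accumulation and immunoassay, with a stated time of 6 min, tested at 10 uM (a lower number here means a stronger effect, a higher number a weaker effect of the compound at the concentration tested), compound 1 gives -17% and compound 2 gives -21%. Of the two numbers, compound 2 has the lower one, with compound 1 nearest; the two lie within the usual scatter of each other, so no order can be read from them. Among the compounds with values here, the one measured step between them, a number 4 percentage points lower from compound 1 to compound 2 (within the scatter), exchanged one aromatic group for another on the same ring nitrogen and left the read-out essentially unchanged.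

Compound 3 `Nc1scc(CN2CCN(c3ccc(F)cc3F)CC2)c1C(=O)c1ccc(Cl)cc1` has not yet been measured in this assay. It differs from compound 2 in one place: 2,4-difluorophenyl in place of naphthalen-1-yl on an amine nitrogen in a ring. Within the data shown here, the only step that bears on this exchange is a number 4 percentage points lower from compound 1 to compound 2 (within the scatter), which stayed within the scatter; two different aromatic groups on this ring nitrogen gave near-identical numbers, and nothing in the data suggests that a third one would behave otherwise. The expectation for this assay is therefore a step of no size beyond the scatter, in no preferred direction, that is a number 2 percentage points higher from compound 2 to compound 3 (within the scatter). For compound 3 the estimate is -19%, with a range from -32% to -6%.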

Compound 3, a percentage reported as activity, at one concentration (the size of the read-out at that concentration, not a potency): -82%
Compound 3: middle estimate off by 63 percentage points, on the high side; measured number below the stated range.
By their numbers in this assay, from the lowest: compound 3; then compounds 2 and 1 (each within the scatter of the next).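

In this assay, the aromatic group on this ring nitrogen proves able to change the read-out strongly: 2,4-difluorophenyl in place of naphthalen-1-yl gives a number 61 percentage points lower from compound 2 to compound 3 (beyond the scatter), and 2,4-difluorophenyl in place of 4-nitrophenyl gives a number 65 percentage points lower from compound 1 to compound 3 (beyond the scatter), which leaves compound 3 with the strongest effect of the three at the concentration tested. The near-identical numbers of compound 1 and compound 2 therefore did not show that this position is insensitive; an aromatic ring on this nitrogen is not enough on its own to produce the effect seen with compound 3, since both of the other compounds carry one and stand far from it. Nothing available explains why this exchange has so large an effect.

The compounds shown do not separate the contribution of the two fluorine atoms from that of having one six-membered aromatic ring in place of two, as the 4-nitrophenyl comparison also changes more than one feature of the group. A plain phenyl group on this nitrogen would be the informative comparison, and a single concentration leaves the potency of compound 3 open.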